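Saturation of the acyl chain in the trimethoxyphenyl amide series

The source may report more compounds than this note shows. Statements on the series, on what has been measured and on what is new or still open speak of the compounds shown alone.

Two compounds have numbers in a functional assay on MGC-803 cells (Homo sapiens) for inhibition, read by MTT assay, with a stated time of 48 h; on this read-out lower numbers stand for stronger inhibition and higher numbers for weaker inhibition. Compound 1 `CCC/C=C/C(=O)N(Cc1ccc(OC)c(O)c1)c1cc(OC)c(OC)c(OC)c1` gives 70 nM, the lowest of the two. Compound 2 `COc1ccc(N(Cc2cc(OC)c(OC)c(OC)c2)C(=O)CCl)cc1O` carries a chloroacetyl group in place of the unsaturated acyl chain and gives 24500 nM; the two structures differ in more than one place, so only the two values themselves are compared, and the gap between them is far beyond the scatter.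

Compound 3 `CCCCC(=O)N(Cc1ccc(OC)c(O)c1)c1cc(OC)c(OC)c(OC)c1` is not yet measured. Against compound 1 it differs by butyl in place of pent-1-en-1-yl on a carbonyl carbon. The double bond outside aromatic rings leaves; the chain shortens from five carbons to four; no donor or acceptor changes; the rest of the molecule, including the amide-type nitrogen and both aryl groups, stays as in compound 1.

Within the data shown here, no single-change step between measured compounds is available to calibrate this change. Removing the double bond from the acyl chain is expected to cost some potency in this assay, on the order of a moderate step upward from compound 1, beyond the scatter but far short of the gap to compound 2. The step from compound 1 to compound 3 is estimated at a 5.7-fold higher number from compound 1 to compound 3 (0.76 log units; beyond the scatter). Compound 3 is therefore expected to give about 400 nM in this assay, with a plausible range from 100 nM to 2000 nM.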

Compound 3, half-maximal inhibitory concentration: 66 nM
For compound 3 the middle estimate is 6.1-fold (0.78 log units) above the measured one, outside the stated range (below it).
By their numbers in this assay, from the lowest: compounds 3 and 1 (each within the scatter of the next); then compound 2.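

In this assay, butyl in place of pent-1-en-1-yl on a carbonyl carbon gives a 1.1-fold lower number from compound 1 to compound 3 (0.03 log units; within the scatter) and so leaves the value where it was. At this position of the series, the double bond outside aromatic rings is therefore not required for activity at the level of compound 1, and the saturated butyl chain serves equally well in this assay. No independent measurement bears on why the two acyl chains perform alike.

Among these compounds, the single step changes both the double bond and the chain, so it cannot show what either change does alone, and pentyl on the same carbonyl carbon would be needed to separate them. Among the compounds shown here, also open is how much more this position accepts, such as a longer chain like octyl or a chain bearing an amine or a carboxylic acid, while compound 2 differs from compound 1 and compound 3 in more than one place, so no step to it can be read.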